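A few compounds are considered here, and "the series" means these few. Any claim that something is new, unique, unknown or untested is made for them only; others in the source may bear on it.

Compound 1 `CCOc1cc(C(C)(C)C)ccc1C1=NC(c2ccc(Cl)cc2)C(c2ccc(Cl)cc2)N1C(=O)N1CCN(Cc2ccc(C(=O)NO)cc2)CC1` gives 3970 nM in a functional assay on MCF7 cells (Homo sapiens) for antiproliferative activity, read by CCK-8 assay, with a stated time of 72 h (on this read-out higher numbers stand for weaker inhibition and lower numbers for stronger inhibition), the lowest of the two numbers in this set; the nearest is compound 3 `CCOc1cc(C(C)(C)C)ccc1C1=NC(c2ccc(Cl)cc2)C(c2ccc(Cl)cc2)N1C(=O)NCCCCCCCC(=O)Nc1ccccc1N`, which gives 20300 nM. Compound 2 `CCOc1cc(C(C)(C)C)ccc1C1=NC(c2ccc(Cl)cc2)C(c2ccc(Cl)cc2)N1C(=O)NCCCCCC(=O)Nc1ccccc1N` returns only a limit, > 100000 nM, sitting at the limit of > 100000 nM in this assay, at which 1 of the 3 values shown sits. Among the compounds with values here, the one measured step, an at least 4.9-fold lower number from compound 2 to compound 3 (0.69 log units; beyond the scatter), concerns a different part of the molecule and does not test the change now followed. Compound 4 `CCOc1cc(C(C)(C)C)ccc1C1=NC(c2ccc(Cl)cc2)C(c2ccc(Cl)cc2)N1C(=O)N1CCN(CCCCCC(=O)NO)CC1` differs from compound 1 in one place: 4-(hydroxycarbamoyl)butyl in place of 4-(hydroxycarbamoyl)phenyl on a saturated chain carbon bound to an amine nitrogen in a ring. Within the data shown here, no measured pair covers this swap, so the expectation rests on the scatter and on the weaker numbers seen for compounds 2 and 3. For compound 4 a somewhat higher number is expected, a 1.8-fold higher number from compound 1 to compound 4 (0.25 log units; within the scatter), giving an estimate of 7000 nM with a range from 2500 nM to 25000 nM.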

Compound 4, half-maximal inhibitory concentration: 7260 nM
Compound 4: the middle estimate sits 1.0-fold (0.02 log units) below what was measured; measured number inside the range.
By their numbers in this assay, from the lowest: compounds 1 and 4 (each within the scatter of the next); then compound 3. At a limit, above all of these: compound 2.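

In this assay replacing the ring with the open chain gives a 1.8-fold higher number from compound 1 to compound 4 (0.26 log units; within the scatter) so at this position, on a saturated chain carbon bound to an amine nitrogen in a ring, 4-(hydroxycarbamoyl)butyl and 4-(hydroxycarbamoyl)phenyl cannot be told apart. The phenyl ring of this substituent is therefore not needed to keep the value at this level. Nothing on hand gives a cause for this result.

Still open, as far as these compounds go, is whether a longer chain ending in hydroxycarbamoyl keeps this level at the same position. Also open, from the compounds shown here alone, is whether a carboxylic acid can replace the hydroxycarbamoyl group on either the butyl or the phenyl substituent.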